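Swapping Chloro for Bromo in a Paw Edema Series

This account rests on a few compounds, and the source may have more. Where it says the series, first, only, none or still open, it means among the compounds named here.

Measured so far:
- compound 1, `CC(=O)c1c(NNc2ccccc2)cc(C)oc1=O`: 55.6%
- compound 2, `CC(=O)c1c(NNc2ccc(Cl)cc2)cc(C)oc1=O`: 58.6%

Both measured compounds were tested in a functional assay on the whole organism for inhibition, with Rattus norvegicus as the target, read by paw edema, with a stated time of 3 h, at a dose of 50 mg/kg; a higher number here means more inhibition at the dose given (going by the name of the read-out), a lower number less inhibition. In this assay compound 1 gives 55.6%, and compound 2 gives 58.6%. Among the compounds with values here, compound 2 stands level with compound 1 on these numbers: the only step between them, a number 3 percentage points higher from compound 1 to compound 2 (within the scatter), was a swap of chloro for hydrogen on the aromatic ring and did not move the read-out beyond the scatter.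

Compound 3, `CC(=O)c1c(NNc2ccc(Br)cc2)cc(C)oc1=O`, has not yet been measured. It differs from compound 2 in one place: bromo in place of chloro on an aromatic carbon. Within the data shown here, no measured step swaps one halogen for another, so the only guide is that the step from hydrogen to chloro, a number 3 percentage points higher from compound 1 to compound 2 (within the scatter), stayed within the scatter. On that slim basis no step beyond the scatter is expected in this assay for compound 3, in either direction, and the estimated change is a number 0.6 percentage points lower from compound 2 to compound 3 (within the scatter). The expected value for compound 3 is therefore 58%, with a range from 45% to 70%.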

Compound 3, a percentage reported as inhibition, in the whole organism at one dose (the size of the read-out at that dose, not a potency): 40.4%
For compound 3 the middle estimate is 17.6 percentage points above the measured one, and the stated range ends above it.
By their numbers in this assay, from the lowest: compound 3; then compounds 1 and 2 (each within the scatter of the next).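

In this assay this aromatic carbon proves less forgiving than the earlier pair suggested: hydrogen and chloro stood level there, yet bromo in place of chloro gives a number 18.2 percentage points lower from compound 2 to compound 3 (beyond the scatter) and is a clear change for a swap of one halogen for the next. The comparison with the unsubstituted compound points the same way, with bromo in place of hydrogen giving a number 15.2 percentage points lower from compound 1 to compound 3 (beyond the scatter) in this assay, so among these three groups at this place only bromo separates from the others, and it does so towards less inhibition of the swelling at the dose given. Nothing available here offers a reason for this drop.

The three compounds cannot say whether the fall belongs to bromo alone or whether other groups on this carbon, such as fluoro, iodo, methyl, methoxy or an amine, would stay level with chloro or fall as bromo does. A single dose and a single reading time also leave open whether the gap seen here would hold at other doses or at other times.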